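The source may hold more compounds than are shown below. What is called first, only, known or untested is meant among the compounds shown, and "the series" means these compounds.

Series in an ADME assay on HEK293 cells (Homo sapiens) for inhibition, read by MTT assay, with a stated time of 2 days; on this read-out higher numbers stand for weaker inhibition and lower numbers for stronger inhibition:
- Compound 1 `Nc1cccc(/C=C/c2cccc(O)c2)c1`: > 100 ug/mL, a limit and not a number
- Compound 2 `COc1cccc(/C=C/c2cccc(O)c2)c1`: 19 ug/mL

Among the compounds with values here, compound 2 holds the only numeric value. The other reading sits at the limit of > 100 ug/mL in this assay, at which 1 of the 2 values shown sits. Compound 3 `COc1cccc(/C=C/c2cccc(N)c2)c1` carries amino in place of hydroxy on an aromatic carbon, meta to a large group (amino in place of hydroxy on an aromatic carbon). Within the data shown here, one measured step bears on this, loosely: an at least 5.2-fold lower number from compound 1 to compound 2 (0.72 log units; beyond the scatter), where amino leaves and methoxy enters. Its size is a bound, and a different group leaves here, so only a modest move to a higher number is expected in this assay. The expected change is a 2.1-fold higher number from compound 2 to compound 3 (0.32 log units; beyond the scatter). The estimate for compound 3 is 40 ug/mL, with an expected range of 12 ug/mL to 100 ug/mL.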

Compound 3, half-maximal inhibitory concentration: 16 ug/mL
The estimate for compound 3 lay 2.5-fold (0.40 log units) above the measured number, within the range that was stated.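

Swapping hydroxy for amino at this position, with methoxy held on the other ring, gives no separable difference in this assay: a 1.2-fold lower number from compound 2 to compound 3 (0.07 log units; within the scatter). With amino held instead, methyl on the oxygen gives an at least 6.2-fold lower number from compound 1 to compound 3 (0.79 log units; beyond the scatter), so this step shows that the methoxy also matters alongside amino. The size of that step is only a bound: the limit of > 100 ug/mL in this assay, at which 1 of the 3 values shown sits.

Open, from the compounds shown here alone, is whether other groups at this position, such as a carboxylic acid or a dimethylamino group, would also read like hydroxy and amino. Also open, going by these compounds, is whether a longer chain such as ethoxy would serve in place of methoxy.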